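This account rests on a few compounds, and the source may have more. Where it says the series, first, only, none or still open, it means among the compounds named here.

Compound 1, `O=C(CSc1nc2c(c(=O)n1-c1ccccc1)SCC2)Nc1nc2ccc(Cl)cc2s1`, gives 40 nM in an assay on L cells for inhibition of Protein-serine O-palmitoleoyltransferase porcupine (Mus musculus), read by reporter gene assay, with a stated time of 24 h; a lower number here means that less compound is needed, a higher number that more compound is needed for the effect.
Compound 2, `COc1ccc(-n2c(SCC(=O)Nc3nc4ccc(OC)cc4s3)nc3c(c2=O)SCC3)cc1`, gives 120 nM in this assay.

In this assay compound 2 stands highest of the two numbers; compound 1 gives the lower number, and that gap lies beyond the usual scatter. Compound 3, `COc1ccc2nc(NC(=O)CSc3nc4c(c(=O)n3-c3ccccc3)SCC4)sc2c1`, differs from compound 2 by hydrogen in place of methoxy on an aromatic carbon. Going by the values given here, no measured pair isolates this change, so its size is uncertain. Compound 3 is expected to move toward a lower number by a step of a 1.8-fold lower number from compound 2 to compound 3 (0.27 log units; within the scatter), modest and perhaps not clearly beyond the scatter. Compound 3 is therefore estimated at 65 nM, with a range from 25 nM to 170 nM.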

Compound 3, half-maximal effective concentration: 40 nM
Compound 3: middle estimate off by 1.6-fold (0.21 log units), on the high side; low and high end bracket the measured number.
By their numbers in this assay, from the lowest: compounds 1 and 3 (each within the scatter of the next); then compound 2.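

Hydrogen in place of methoxy on the phenyl, read in this assay, gives a 3.0-fold lower number from compound 2 to compound 3 (0.48 log units; beyond the scatter) and so shows for the first time that this carbon, para to a large group, responds to the change. At a second aromatic carbon, methoxy in place of chloro gives no change at the digits printed from compound 1 to compound 3 (within the scatter) and shows that the two groups read alike there. No measurement shown here accounts for either step. Left open is how an amine or a fluoro on that phenyl carbon would read. Also open, as far as these compounds go, is whether the same step holds with chloro at the second carbon.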